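This account rests on a few compounds, and the source may have more. Where it says the series, first, only, none or still open, it means among the compounds named here.

Among the compounds with values here, compound 2 `O=C(/C=C\Nc1ccc(Cl)cc1)c1cn(-c2ccccc2)nc1-c1ccc(Cl)cc1` is the only compound of the two measured that gives a number in a functional assay on PC-3 cells (Homo sapiens) for antiproliferative activity, read by MTT assay, with a stated time of 48 h; on this read-out lower numbers stand for stronger inhibition and higher numbers for weaker inhibition: compound 2 gives 3890 nM. Compound 1 `O=C(/C=C\Nc1ccc(F)cc1)c1cn(-c2ccccc2)nc1-c1ccc(Cl)cc1` reaches only a limit in this assay, > 50000 nM (the limit of > 50000 nM in this assay, at which 1 of the 2 values shown sits). Within the data shown here, the single measured step, an at least 12-fold lower number from compound 1 to compound 2 (1.10 log units; beyond the scatter), shows that the group on this ring moves the read-out strongly. Compound 3 `O=C(/C=C\Nc1ccc(O)cc1)c1cn(-c2ccccc2)nc1-c1ccc(Cl)cc1` carries the change (hydroxy in place of chloro on an aromatic carbon). Among the measured compounds shown here, no measured step exchanges a halogen for hydroxy, so the halogen step is the only guide. Compound 3 is expected to come out weaker than compound 2, a 3.9-fold higher number from compound 2 to compound 3 (0.59 log units; beyond the scatter), with an estimated 15000 nM ranging from 3000 nM to 50000 nM.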

Compound 3, half-maximal inhibitory concentration: 4430 nM
The estimate for compound 3 lay 3.4-fold (0.53 log units) above the measured number; measured number inside the range.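

In this assay, the exchange of chloro for hydroxy on this ring gives a 1.1-fold higher number from compound 2 to compound 3 (0.06 log units; within the scatter), so a halogen is not required here, and the added hydrogen-bond donor leaves the read-out within the scatter. Fluoro alone stands apart among the three groups, with an at least 11-fold lower number from compound 1 to compound 3 (1.05 log units; beyond the scatter) matching the gap seen with chloro. Compound 1 gives a limit rather than a number: the limit of > 50000 nM in this assay, at which 1 of the 3 values shown sits.

Open, on these data alone, is whether an amine, a methoxy group or a carboxylic acid at this place stays level with compound 2 and compound 3. Also open, as far as these compounds go, is whether bromo does the same.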